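A few compounds are considered here, and "the series" means these few. Any claim that something is new, unique, unknown or untested is made for them only; others in the source may bear on it.

In an assay for inhibition of histone-lysine N-methyltransferase EZH2 variant Y641N (Homo sapiens), read by scintillation counting, with a stated time of 60 min, in the presence of a further agent that is not named here (a lower number here means a stronger inhibitor, a higher number a weaker inhibitor), compound 2 `Cc1cc(C)c(CN2CCc3c(Cl)cc([C@@H](CO)[C@@H]4CCCO4)c(Cl)c3C2=O)c(=O)[nH]1` gives 135 nM, the lowest of the two single numbers shown. Compound 1 `Cc1cc(C)c(CN2CCc3c(Cl)cc([C@@H](CO)[C@@H]4CCOC4)c(Cl)c3C2=O)c(=O)[nH]1` gives 1260 nM, and the step of a 9.3-fold lower number from compound 1 to compound 2 (0.97 log units; beyond the scatter) separates them. Compound 3 `COC(c1cc(Cl)c2c(c1Cl)C(=O)N(Cc1c(C)cc(C)[nH]c1=O)CC2)C1CCN(C2COC2)CC1` gives 530 nM; 0.64 nM (2 entries), two entries far apart, so no single number stands for it. Compound 4 `Cc1cc(C)c(CN2CCc3c(Cl)cc(-c4c(C)noc4C)c(Cl)c3C2=O)c(=O)[nH]1` is not yet measured; it differs from compound 2 by a group of 7 heavy atoms (5 carbon, 1 nitrogen, 1 oxygen; one five-membered aromatic ring with 2 hetero atoms) in place of a group of 8 heavy atoms (6 carbon, 2 oxygen; one five-membered non-aromatic ring with 1 hetero atom), on an aromatic carbon. Among the measured compounds shown here, the only measured step moves one saturated ring to another and does not cover an exchange for an aromatic ring, so it bears only loosely on this change. A moderate gain is expected, with wide uncertainty, as a 2.7-fold lower number from compound 2 to compound 4 (0.43 log units; beyond the scatter). Compound 4 is estimated at 50 nM, within 5 nM to 500 nM.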

Compound 4, inhibition constant: 1.15 nM
Beside the measured number, compound 4's estimate is 43-fold (1.64 log units) above it, and the stated range ends above it.
By their numbers in this assay, from the lowest: compound 4; then compound 2; then compound 1.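

On this aromatic carbon, a ring change can matter far more than the saturated-ring swap a 9.3-fold lower number from compound 1 to compound 2 (0.97 log units; beyond the scatter) suggested. In this assay, the 3,5-dimethyl-1,2-oxazol-4-yl group gives a 120-fold lower number from compound 2 to compound 4 (2.07 log units; beyond the scatter) and a 1100-fold lower number from compound 1 to compound 4 (3.04 log units; beyond the scatter). The group that leaves has a hydrogen-bond donor and the one that enters has none, so a donor here is not needed for a low number in this assay. Nothing given here shows which feature of the new group accounts for the gain. Going by these compounds, a phenyl ring, or the same oxazole ring without its two methyl groups, remains open.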